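This account rests on a few compounds, and the source may have more. Where it says the series, first, only, none or still open, it means among the compounds named here.

Working notes on a small set of chlorobenzyl purine analogues tested in a functional assay on NCI-H226 cells (Homo sapiens) for cytotoxicity, read by sulforhodamine B assay, with a stated time of 48 h; a lower number here means that less compound is tolerated, a higher number that more compound is tolerated.

Compound 1 `ClCc1ccc(Cn2cnc3c(Cl)ncnc32)cc1` gives 49000 nM in this assay, the highest of the three numbers recorded. Compound 3 `ClCc1cccc(Cn2cnc3c(Cl)nc(Cl)nc32)c1` gives 40700 nM in this assay, a value within the scatter of that of compound 1, so no order can be read between these two. Compound 2 `ClCc1ccc(Cn2cnc3nc(Cl)nc(Cl)c32)cc1` gives 15500 nM in this assay, a lower number than compound 1 by a margin beyond the scatter, so compound 2 is tolerated less well than compound 1.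

Compound 4 `ClCc1ccc(Cn2cnc3c(Cl)nc(Cl)nc32)cc1` has not yet been measured in this assay. It differs from compound 1 by chloro in place of hydrogen on an aromatic carbon. Among the compounds with values here, no measured pair in the set isolates this single change, so the size of the step rests on indirect comparison: compound 3 carries the same two chloro groups on the core as compound 4 and sits within the scatter of compound 1.

The expected step is a 1.4-fold lower number from compound 1 to compound 4 (0.15 log units; within the scatter), which is no change beyond the scatter. Compound 4 is estimated at 35000 nM in this assay, with a range from 12000 nM to 90000 nM.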

Compound 4, concentration lethal to 50% of the cells: 33900 nM
Estimate against measurement, compound 4: 1.0-fold (0.01 log units) above; measured number inside the range.
By their numbers in this assay, from the lowest: compound 2; then compounds 4, 3 and 1 (each within the scatter of the next).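

In this assay, within the data shown here, chloro in place of hydrogen on an aromatic carbon between two ring nitrogen atoms gives a 1.4-fold lower number from compound 1 to compound 4 (0.16 log units; within the scatter) and this is the first step that isolates a single change. The step lies within the scatter, so at this position of the shared core the chloro and hydrogen compounds cannot be told apart in this read-out, a finding that rests on this one pair alone. No measured evidence bears on this result.

On these data alone, whether an amine or a methoxy group at the same position would give a step beyond the scatter remains open. Also open, as far as these compounds go, is whether chloro and hydrogen would still give values within the scatter if the other chloro on that ring were replaced by an amine.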